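Notes on the step from compound 3 to compound 4

A few compounds are considered here, and "the series" means these few. Any claim that something is new, unique, unknown or untested is made for them only; others in the source may bear on it.

Values in an ADME assay on BCBL1 cells (Homo sapiens) for cytotoxicity, with a stated time of 7 days (a higher number here means that more compound is tolerated, a lower number that less compound is tolerated), for the measured compounds:
- compound 1 `C=CCOc1nc(N)nc2c1ncn2/C=C1/CC1(CO)CO` gives > 20000 nM as a limit
- compound 2 `CCCCCCCCOc1nc(N)nc2c1ncn2/C=C1/CC1(CO)CO` gives > 20000 nM as a limit
- compound 3 `Nc1nc(NC2CCCC2)c2ncn(/C=C3/CC3(CO)CO)c2n1` gives 71700 nM as a number

Among the measured compounds shown here, compound 3 carries the only number, and the sole other reference is the limit of > 20000 nM in this assay, at which 2 of the 3 values shown sit, for this series. The change to compound 4 `CC(C)CNc1nc(N)nc2c1ncn2/C=C1/CC1(CO)CO` is isobutyl in place of cyclopentyl on a nitrogen on an aromatic ring and amounts to isobutyl in place of cyclopentyl on a nitrogen on an aromatic ring. The measured steps are a step that the two limits leave unreadable from compound 1 to compound 2 and a step that the limit leaves unreadable from compound 1 to compound 3 and a step that the limit leaves unreadable from compound 2 to compound 3 and none of them gives a size. With compound 3 at 71700 nM as the only anchor, no step beyond the scatter is expected in this assay for this change. The expected change is a 1.2-fold lower number from compound 3 to compound 4 (0.08 log units; within the scatter) and it has no direction that the data support. Compound 4 is estimated at 60000 nM with an expected range from 25000 nM to 140000 nM in this read-out.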

Compound 4, half-maximal cytotoxic concentration: > 20000 nM
Compound 4: only a limit was reported (the forecaster's own chance of this, stated with the estimate: 35%); the middle value is on the limit's open side.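

Among the compounds shown here, compound 4 is reported only as a limit, and no step from compound 1, compound 2 or compound 3 to it can be read in this assay. The compounds shown leave open whether isobutylamino, cyclopentylamino, allyloxy and octyloxy differ at all in this read-out, with most of the series at one limit: the limit of > 20000 nM in this assay, at which 3 of the 4 values shown sit.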